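The source may hold more compounds than are shown below. What is called first, only, known or untested is meant among the compounds shown, and "the series" means these compounds.

Compound 1 `CN1C/C(=C\c2ccncc2)C(=O)/C(=C/c2ccccc2F)C1`: 7000 nM
Compound 2 `O=C1/C(=C/c2ccncc2)CN(S(=O)(=O)c2ccccc2)C/C1=C\c1ccccc1F`: 17500 nM
Compound 3 `Cc1ccc(S(=O)(=O)N2C/C(=C\c3ccncc3)C(=O)/C(=C/c3ccccc3F)C2)cc1`: 13200 nM

In a functional assay on SMMC-7721 cells (Homo sapiens) for cytotoxicity, read by MTT assay, with a stated time of 24 h (on this read-out lower numbers stand for stronger inhibition and higher numbers for weaker inhibition), compound 3 gives 13200 nM and sits within the scatter of both other compounds (a 1.9-fold higher number from compound 1 to compound 3 (0.28 log units; within the scatter); a 1.3-fold lower number from compound 2 to compound 3 (0.12 log units; within the scatter)). Only the outer pair stands clearly apart (a 2.5-fold higher number from compound 1 to compound 2 (0.40 log units; beyond the scatter)).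

Compound 4 `O=C1/C(=C/c2ccncc2)CN(S(=O)(=O)c2ccc(C(F)(F)F)cc2)C/C1=C\c1ccccc1F` differs from compound 3 in one group: trifluoromethyl in place of methyl on an aromatic carbon, para to a large group (trifluoromethyl in place of methyl on an aromatic carbon). The most relevant measured change sits on that same carbon, where methyl replaces hydrogen (a 1.3-fold lower number from compound 2 to compound 3 (0.12 log units; within the scatter)). Among the compounds with values here, that step stays within the scatter, while the only step beyond it, a modest one, comes from replacing methyl on the ring nitrogen. Within the data shown here, no measured compound carries trifluoromethyl, so this evidence is indirect. No shift beyond the scatter is therefore expected in this assay.

The estimated step is a 1.1-fold lower number from compound 3 to compound 4 (0.02 log units; within the scatter).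

For compound 4 the expected value is 12500 nM, with an estimated range from 6000 nM to 26000 nM.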

Compound 4, half-maximal inhibitory concentration: 11100 nM
For compound 4 the middle estimate is 1.1-fold (0.05 log units) above the measured one; the range from low to high includes it.
By their numbers in this assay, from the lowest: compounds 1, 4, 3 and 2 (each within the scatter of the next, the first and the last beyond it).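

In this assay, trifluoromethyl on this aromatic carbon, para to a large group, stays within the scatter of both methyl (a 1.2-fold lower number from compound 3 to compound 4 (0.08 log units; within the scatter)) and hydrogen (a 1.6-fold lower number from compound 2 to compound 4 (0.20 log units; within the scatter)). Compound 3 alone had shown this only for a swap of hydrogen for methyl, so the finding now extends to a group with more heavy atoms, and these three compounds cannot be told apart at this position. Nothing available explains this lack of separation or links it to any property of the groups.

Going by these compounds, whether an amine, a carboxylic acid or a longer chain on the same carbon would move the number beyond the scatter stays open. Also open, on these data alone, is whether hydrogen, methyl and trifluoromethyl would stay this close in another cell line or over a longer exposure.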